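Changing the Aromatic Group on the Ring Nitrogen

The compounds below may be only part of what the source reports. "The series", "measured", "known", "first", "only" and "open" are said of these compounds alone.

Three compounds share one core and differ only in the aromatic group attached to an amine nitrogen in a ring. Compound 1 `CCCc1nc(-c2ccccc2)c(CNCCCN2CCN(c3ccccc3F)CC2)o1` gives 54.4% in an assay on HEK293 cells for inhibition of Voltage-dependent T-type calcium channel subunit alpha-1G (Homo sapiens), read by fluorescence, tested at 10 uM; a higher number here means more inhibition at the concentration tested (going by the name of the read-out), a lower number less inhibition. Compound 2 `CCCc1nc(-c2ccccc2)c(CNCCCN2CCN(c3ccccc3C(F)(F)F)CC2)o1` gives 45%, and compound 3 `CCCc1nc(-c2ccccc2)c(CNCCCN2CCN(c3cccc(C(F)(F)F)c3)CC2)o1` gives 51.6%. On the bare numbers compound 3 falls between the other two, nearest to compound 1 and furthest from compound 2, yet every gap among the three lies within the scatter: a number 9.4 percentage points lower from compound 1 to compound 2 (within the scatter), a number 2.8 percentage points lower from compound 1 to compound 3 (within the scatter) and a number 6.6 percentage points higher from compound 2 to compound 3 (within the scatter). Compound 4 `CCCc1nc(-c2ccccc2)c(CNCCCN2CCN(c3ccc(Cl)cc3)CC2)o1` has not been measured. It differs from compound 3 by 4-chlorophenyl in place of 3-(trifluoromethyl)phenyl on an amine nitrogen in a ring. The two earlier steps that exchange one aromatic group for another on this ring nitrogen, from compound 1 to compound 3 and from compound 2 to compound 3, both stayed within the scatter, so no step beyond the scatter is expected in this assay here either. Compound 4 is therefore estimated at 50%, with a range from 35% to 65%, which means an expected step of a number 1.6 percentage points lower from compound 3 to compound 4 (within the scatter).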

Compound 4, a percentage reported as inhibition, at one concentration (the size of the read-out at that concentration, not a potency): 63.3%
Estimate against measurement, compound 4: 13.3 percentage points below; measured number inside the range.
By their numbers in this assay, from the lowest: compounds 2, 3, 1 and 4 (each within the scatter of the next, the first and the last beyond it).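

For the compounds shown here, this is the first exchange at this ring nitrogen to move the number beyond the scatter in this assay: 4-chlorophenyl gives a number 11.7 percentage points higher from compound 3 to compound 4 (beyond the scatter) and a number 18.3 percentage points higher from compound 2 to compound 4 (beyond the scatter), so the choice of aromatic group here can register in this assay. The same group gives a number 8.9 percentage points higher from compound 1 to compound 4 (within the scatter), so compound 4 stands clear of the two compounds with a trifluoromethyl group but cannot be placed above compound 1, which carries 2-fluorophenyl. Across all four groups the number in this assay therefore shows a modest separation only at the two ends of the series.

As far as these compounds go, how 4-bromophenyl, 4-methoxyphenyl or 4-(trifluoromethyl)phenyl would read on this nitrogen remains open, as does whether the chlorine itself or its place on the ring matters more. Nothing available here explains the difference between these groups.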